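Quinoline-methyl imidazopyridine series: aryl swap at the fluoro-bearing ring

This account rests on a few compounds, and the source may have more. Where it says the series, first, only, none or still open, it means among the compounds named here.

Measured compounds:
- compound 1 `Cn1cc(-c2cc(C#N)c3ncc(Cc4ccc5ncccc5c4)n3c2)cn1`: "not determined" (no result reported) in a functional assay on EBC-1 cells (Homo sapiens) for antiproliferative activity, with a stated time of 72 h; on this read-out lower numbers stand for stronger inhibition and higher numbers for weaker inhibition
- compound 2 `Cn1cc(-c2cc(F)c3ncc(Cc4ccc5ncccc5c4)n3c2)cn1`: 0.27 nM

Compound 2 stands as the only numbered entry on this read-out, so it carries no rank; compound 1 contributes no number and cannot be set against it. In this assay compound 2 gives 0.27 nM, a very low concentration.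

Compound 3 `CNC(=O)c1cccc(-c2cc(F)c3ncc(Cc4ccc5ncccc5c4)n3c2)c1` is the next compound to be measured. It differs from compound 2 as follows: 3-(methylcarbamoyl)phenyl in place of 1-methyl-1H-pyrazol-4-yl on an aromatic carbon The place of the change is an aromatic carbon of the fused core, meta to the fluoro group, with the remainder of the molecule left untouched.

For the measured compounds named here, no step between measured compounds is available, so the size of the expected step rests on the structural change alone. A moderate weakening is expected, of a size that may or may not exceed the usual scatter, since a larger group with a hydrogen-bond donor replaces the small pyrazole. The estimated step from compound 2 to compound 3 is a 3.7-fold higher number from compound 2 to compound 3 (0.57 log units; beyond the scatter). Compound 3 is expected to give about 1 nM, in a range from 0.2 nM to 6 nM.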

Compound 3, half-maximal inhibitory concentration: 400 nM
For compound 3 the middle estimate is 400-fold (2.60 log units) below the measured one; the whole stated range lies below it.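

In this assay, the aromatic carbon two atoms from the ring nitrogen and meta to a fluoro group proves highly sensitive to the group it carries: 3-(methylcarbamoyl)phenyl in place of 1-methyl-1H-pyrazol-4-yl gives a 1500-fold higher number from compound 2 to compound 3 (3.17 log units; beyond the scatter), a large weakening. An aromatic ring at this carbon is therefore not enough in itself to keep the sub-nanomolar level of compound 2, since compound 3 also has one there and still lands far higher. For the compounds shown here, the single swap changes the ring and adds the methylcarbamoyl group at once, and nothing measured on these compounds accounts for the size of the step.

From the compounds shown here alone, how much of the loss belongs to the change of ring and how much to the methylcarbamoyl group stays open; a plain phenyl, or a 1-methyl-1H-pyrazol-4-yl replaced by a pyridine or a phenyl bearing an amine, would begin to separate the two. The role of the fluoro group is also unresolved, as compound 1, with a nitrile in its place, carries no number on this read-out.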